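The source may hold more compounds than are shown below. What is called first, only, known or untested is meant among the compounds shown, and "the series" means these compounds.

Compound 1, `CC(O)(C#Cc1cccc(Nc2ncnc3[nH]ccc23)c1)c1nccs1`, gives 1640 nM in an assay for inhibition of mitogen-activated protein kinase kinase kinase 14 (Homo sapiens), read by luminescence and ADP-Glo, with a stated time of 120 min, in the presence of a further agent that is not named here; on this read-out higher numbers stand for weaker inhibition and lower numbers for stronger inhibition.
Compound 2, `C[C@@H]1CN(c2ccc(C#CC(C)(O)c3nccs3)cc2Nc2ncnc3[nH]ccc23)CCN1`, gives 210 nM in this assay.
Compound 3, `CN1CCN(c2ccc(C#CC(C)(O)c3nccs3)cc2Nc2ncnc3[nH]ccc23)CC1`, gives 78.3 nM in this assay.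

Compound 3 stands at the lowest of the three numbers in this assay: compound 2 is nearest, with a 2.7-fold lower number from compound 2 to compound 3 (0.43 log units; beyond the scatter), and compound 1 furthest, with a 21-fold lower number from compound 1 to compound 3 (1.32 log units; beyond the scatter). Compound 4, `CCS(=O)(=O)N1CCN(c2ccc(C#CC(C)(O)c3nccs3)cc2Nc2ncnc3[nH]ccc23)CC1`, is not yet measured. It differs from compound 3 by ethylsulfonyl in place of methyl on an amine nitrogen in a ring. For the measured compounds named here, no measured step changes the group on this ring nitrogen in the same way. The steps of a 7.8-fold lower number from compound 1 to compound 2 (0.89 log units; beyond the scatter) and a 21-fold lower number from compound 1 to compound 3 (1.32 log units; beyond the scatter) show what the whole piperazine ring brought, and the step of a 2.7-fold lower number from compound 2 to compound 3 (0.43 log units; beyond the scatter) shows that a different placing of the methyl on that ring was a modest step. Compound 4 keeps the ring and alters only the group on its nitrogen, so the data give no direct guide, and a modest shift in either direction is plausible, with a slight weakening taken as the more likely outcome. Compound 4 is estimated at 150 nM, within a range of 40 nM to 600 nM. This estimate is expected to mean a 1.9-fold higher number from compound 3 to compound 4 (0.28 log units; within the scatter).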

Compound 4, half-maximal inhibitory concentration: 8.22 nM
Compound 4: middle estimate off by 18-fold (1.26 log units), on the high side; measured number outside the range, below it.
By their numbers in this assay, from the lowest: compound 4; then compound 3; then compound 2; then compound 1.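

In this assay, for the compounds shown here, the ring nitrogen of the piperazine proves far more responsive than the earlier compounds could show, since ethylsulfonyl in place of methyl gives a 9.5-fold lower number from compound 3 to compound 4 (0.98 log units; beyond the scatter) and the number falls rather than rises. The same group also carries the wider comparisons, with 4-(ethylsulfonyl)piperazin-1-yl in place of 3-methylpiperazin-1-yl giving a 26-fold lower number from compound 2 to compound 4 (1.41 log units; beyond the scatter) and in place of hydrogen on the aromatic carbon giving a 200-fold lower number from compound 1 to compound 4 (2.30 log units; beyond the scatter) in this series. This nitrogen thus accepts a group of five heavy atoms, with two hydrogen-bond acceptors, and the number still goes down. On these data alone, whether the step belongs to the sulfonyl or to the ethyl stays open, as does how methylsulfonyl, acetyl or a plain ethyl on this nitrogen would read. Nothing given here bears on why the number falls.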